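The compounds below may be only part of what the source reports. "The series", "measured", "known", "first", "only" and "open" are said of these compounds alone.

Working notes on the series. Of the compounds shown here, three have been measured in a functional assay on A549 cells (Homo sapiens) for inhibition, read by CCK-8 assay, with a stated time of 72 h, tested at 2 uM; a lower number here means less inhibition of growth, a higher number more inhibition of growth at the concentration tested. Compound 1 `Cc1cc(C)cc(SCc2ccc(/C=C/C(=O)Nc3ccccc3N)cc2)c1` gives in this assay a value of 46.1%. Compound 2 `Nc1ccccc1NC(=O)/C=C/c1ccc(CSc2ccc(Cl)cc2)cc1` gives in this assay a value of 55.3%. Compound 3 `Nc1ccccc1NC(=O)c1ccc(CSc2ccc(Cl)cc2)cc1` gives in this assay a value of 47.3%. Compound 2 and compound 3 differ in their cores; the difference between the two cores is not broken down here, and their two numbers lie within the scatter of each other. Compound 3 likewise lies within the scatter of compound 1.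

Among the measured compounds shown here, the one counted change among the measured compounds is 3,5-dimethylphenyl in place of 4-chlorophenyl on a sulfur. It produced a step of a number 9.2 percentage points lower from compound 2 to compound 1 (within the scatter), which stays within the scatter, so no direction is read from it.

Compound 4 `Cc1cc(C)cc(SCc2ccc(C(=O)Nc3ccccc3N)cc2)c1` is still to be measured in this assay. It differs from compound 3 by 3,5-dimethylphenyl in place of 4-chlorophenyl on a sulfur. The place is the same word for word as in the earlier pair, so this is the same change, now made on the core of compound 3. The expected step is estimated as a number 7.3 percentage points lower from compound 3 to compound 4 (within the scatter). For the measured compounds named here, the expectation rests on a single precedent, because a number 9.2 percentage points lower from compound 2 to compound 1 (within the scatter) is the only measured instance of this change, and that step fell within the scatter. Compound 4 is accordingly expected to give 40% in this assay, with the estimate spanning from 28% to 52%.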

Compound 4, percent growth inhibition at one concentration: 33.3%
Compound 4: middle estimate off by 6.7 percentage points, on the high side; the range from low to high includes it.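

Carried onto the second core, 3,5-dimethylphenyl in place of 4-chlorophenyl on a sulfur gives in this assay a step of a number 14 percentage points lower from compound 3 to compound 4 (beyond the scatter), the only instance of this change that lies beyond the scatter. The two instances point the same way, and the size of the step shows no measurable dependence on the core: the same change on two cores in this assay, a number 9.2 percentage points lower (within the scatter) from compound 2 to compound 1 and a number 14 percentage points lower (beyond the scatter) from compound 3 to compound 4, 4.8 percentage points apart, within the scatter of two such steps

This supports carrying the change between these two cores only; it rests on a single pair of groups and on two steps, one of which stays within the scatter when read alone, and it shows neither a reason for the step nor that the step would hold on any other core.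

The compounds shown carry only 4-chlorophenyl and 3,5-dimethylphenyl on the sulfur, so it remains open whether the step follows the loss of the chlorine or the entry of the methyl groups. Also open, going by these compounds, is how either core would respond to an amine or a carboxylic acid on that ring, or to a longer chain joining the ring to the sulfur.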